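Swapping Chloro for Nitro on the Benzyl Ring

A few compounds are considered here, and "the series" means these few. Any claim that something is new, unique, unknown or untested is made for them only; others in the source may bear on it.

Compound 1 `COc1cccc(OC)c1OCCNCCOc1ccccc1OCc1cccc(Cl)c1`: 5900 nM
Compound 2 `COc1cccc(OC)c1OCCNCCOc1ccccc1OCc1ccc(Cl)cc1`: 2400 nM

In a functional assay on PC-3 cells (Homo sapiens) for cytotoxicity, read by sulforhodamine B assay (on this read-out lower numbers stand for stronger inhibition of growth and higher numbers for weaker inhibition of growth), compound 2 gives the lowest of the two numbers shown, with compound 1 giving 5900 nM as the nearest, a step of a 2.5-fold lower number from compound 1 to compound 2 (0.39 log units; beyond the scatter). Compound 3 `COc1cccc(OC)c1OCCNCCOc1ccccc1OCc1ccc([N+](=O)[O-])cc1` differs from compound 2 by nitro in place of chloro on an aromatic carbon. Among the compounds with values here, the one measured step concerns only the position of chloro, not its exchange for another group, so no measured step bears on this change. The expected step is a 1.3-fold higher number from compound 2 to compound 3 (0.10 log units; within the scatter), with wide uncertainty. Compound 3 is therefore estimated at 3000 nM, with a range from 1000 nM to 9000 nM.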

Compound 3, concentration for 50% growth inhibition: 12000 nM
Compound 3: middle estimate off by 4.0-fold (0.60 log units), on the low side; the whole stated range lies below it.
By their numbers in this assay, from the lowest: compound 2; then compound 1; then compound 3.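

In this assay, nitro does not serve as a replacement for chloro at this place on the ring: the step of a 5.0-fold higher number from compound 2 to compound 3 (0.70 log units; beyond the scatter) shows a clear loss of growth inhibition. Moving chloro had cost less in the earlier pair, and compound 3 also falls behind the weaker chloro compound, with the step of a 2.0-fold higher number from compound 1 to compound 3 (0.31 log units; beyond the scatter) still beyond the usual scatter. Nothing available explains why this exchange weakens the effect. Going by these compounds, how an amine or a carboxylic acid at this same place would compare with chloro and nitro remains open. So does whether nitro elsewhere on the ring would give the same loss.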